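Chloro to Fluoro on the Aromatic Ring: Expected Clearance

The source may report more compounds than this note shows. Statements on the series, on what has been measured and on what is new or still open speak of the compounds shown alone.

Compound 1 `O=[N+]([O-])c1cn2c(n1)OC[C@@H](NCc1ccc(OC(F)(F)F)c(Cl)c1)C2` was tested in an in vitro ADME assay on the whole organism (microsomes, liver, Mus musculus) for metabolic stability, read by LC-MS, with a stated time of 24 h, at a dose of 5 mg/kg by the intravenous route (on this read-out lower numbers stand for slow clearance and higher numbers for fast clearance), where compound 1 gives 103 mL.min-1.g-1. Compound 2 `CCCN(Cc1ccc(OC(F)(F)F)cc1)[C@@H]1COc2nc([N+](=O)[O-])cn2C1` was tested in the same setting, and in this assay compound 2 gives 407 mL.min-1.g-1. Of the two numbers shown, compound 1 stands lowest; its nearest neighbour is compound 2, whose higher number lies beyond the usual scatter of repeat measurements.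

Compound 3 `O=[N+]([O-])c1cn2c(n1)OC[C@@H](NCc1ccc(OC(F)(F)F)c(F)c1)C2` has not yet been measured in this assay. It differs from compound 1 in one place: fluoro in place of chloro on an aromatic carbon. One heavy atom leaves and one enters, on an aromatic carbon of a six-membered aromatic ring of carbon only, ortho to a trifluoromethoxy group, and the hydrogen-bond donor and acceptor counts stay unchanged.

Going by the values given here, no pair of measured compounds shows this particular change, so no measured step tells its size. The expected step in this assay is a 1.2-fold higher number from compound 1 to compound 3 (0.07 log units; within the scatter), which is not beyond the scatter in either direction. For compound 3 in this assay the estimated value is 120 mL.min-1.g-1, with a range from 60 mL.min-1.g-1 to 240 mL.min-1.g-1.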

Compound 3, intrinsic clearance in microsomes: 58.7 mL.min-1.g-1
For compound 3 the middle estimate is 2.0-fold (0.31 log units) above the measured one, outside the stated range (below it).
By their numbers in this assay, from the lowest: compounds 3 and 1 (each within the scatter of the next); then compound 2.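

In this assay, going by these compounds alone, the exchange of chloro for fluoro on this aromatic carbon, ortho to a trifluoromethoxy group, gives a 1.8-fold lower number from compound 1 to compound 3 (0.24 log units; within the scatter), and this is the first measured step at this place. On this read-out, compound 1 and compound 3 cannot be told apart, so this exchange of one heavy atom for another, with the hydrogen-bond donor and acceptor counts unchanged, does not separate the two compounds. Nothing measured here explains why the two compounds read alike or links the result to any feature of either group.

The compounds shown leave open whether a nitrile, a methyl group, a methoxy group or a plain hydrogen on this same aromatic carbon would read like chloro and fluoro or would stand clearly apart from them. Going by these compounds, it also remains open whether the exchange of chloro for fluoro would give a step of similar size if a trifluoromethyl group or a methoxy group took the place of the trifluoromethoxy group.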